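Methyl for Hydrogen on the Aromatic Ring of Compound 3

The compounds below may be only part of what the source reports. "The series", "measured", "known", "first", "only" and "open" are said of these compounds alone.

The series begins with three measured compounds. Compound 1 `COc1nc(OC)nc(Sc2ccccc2C(=O)O)n1` gives -14.3% in an assay for inhibition of Pro-cathepsin H (Homo sapiens), read by fluorescence, tested at 50 uM; a higher number here means more inhibition at the concentration tested (going by the name of the read-out), a lower number less inhibition. Compound 2 `COc1nc(OC)nc(Sc2ccccc2C(=O)N[C@@H](C)C(=O)OCc2ccccc2)n1` gives 1.34% in this assay. Compound 3 `O=c1nc(-c2ccccc2)nc(S)[nH]1` gives 4.86% in this assay, the highest of the three numbers; the value of compound 2 lies within the scatter of it, while the value of compound 1 lies beyond the scatter below it. Since no two of these compounds differ in one place only, no single step can be read from them.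

Compound 4 `Cc1ccc(-c2nc(S)[nH]c(=O)n2)cc1` is not yet measured. It differs from compound 3 by one counted change: methyl in place of hydrogen on an aromatic carbon In this assay, a methyl in place of hydrogen on an aromatic carbon is expected to move the number little, with no step beyond the scatter in either direction, because compound 3 itself gives 4.86% and nothing measured points elsewhere. Compound 4 is therefore estimated at 5%, within the range -10% to 20%, meaning an expected step of a number 0.1 percentage points higher from compound 3 to compound 4 (within the scatter).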

Compound 4, a percentage reported as inhibition, at one concentration (the size of the read-out at that concentration, not a potency): 6.58%
Beside the measured number, compound 4's estimate is 1.6 percentage points below it; low and high end bracket the measured number.
By their numbers in this assay, from the lowest: compound 1; then compounds 2, 3 and 4 (each within the scatter of the next).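

Methyl in place of hydrogen on an aromatic carbon, para to a group of 8 heavy atoms, gives the series its first step that can be read, a number 1.7 percentage points higher from compound 3 to compound 4 (within the scatter) in this assay. The earlier compounds shown here could not show this, as no two of them differ in one place only; here a single added methyl at this position leaves the number within the scatter. No measurement shown here bears on this result.

Going by these compounds, what a larger change at the same place would do stays open: a longer chain such as butyl, an amine or a chlorine atom could each give a step of a different size. Also open, on these data alone, is whether a methyl on another aromatic carbon of this ring would leave the number within the scatter too.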